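This account rests on a few compounds, and the source may have more. Where it says the series, first, only, none or still open, it means among the compounds named here.

In a functional assay on HT-29 cells (Homo sapiens) for inhibition, read by MTT assay, with a stated time of 72 h; on this read-out lower numbers stand for stronger inhibition and higher numbers for weaker inhibition:
- Compound 1 `CC(C)CNC(=C\C(=O)/C=C/c1ccc(O)cc1)/C=C/c1ccc(O)cc1`: 20100 nM
- Compound 2 `CCC(C)NC(=C\C(=O)/C=C/c1ccc(O)cc1)/C=C/c1ccc(O)cc1`: 13000 nM
- Compound 3 `CCC(C)NC(=C\C(=O)/C=C/c1ccc(OC(C)=O)c(OC)c1)/C=C/c1ccc(OC(C)=O)c(OC)c1`: > 25000 nM

The entry for compound 3 is a limit of the assay and not a number.

For the measured compounds named here, compound 2, at 13000 nM, is one of only two compounds with a true number, and the other is compound 1. The gap between them is small: a 1.5-fold lower number from compound 1 to compound 2 (0.19 log units; within the scatter).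

Compound 4 `O=C(/C=C(/C=C/c1ccc(O)cc1)NC1CCCCC1)/C=C/c1ccc(O)cc1` has cyclohexyl in place of sec-butyl on an amine nitrogen.

Going by the values given here, the only measured swap of this group, a 1.5-fold lower number from compound 1 to compound 2 (0.19 log units; within the scatter), gives little guide, and no measured step brings in a ring. In this assay, no change beyond the scatter is therefore expected, and the expected step is a 1.1-fold lower number from compound 2 to compound 4 (0.03 log units; within the scatter). For compound 4 the estimate is 12000 nM, with an expected range of 5500 nM to 25000 nM.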

Compound 4, half-maximal inhibitory concentration: 4000 nM
Compound 4: the middle estimate sits 3.0-fold (0.48 log units) above what was measured; the whole stated range lies above it.
By their numbers in this assay, from the lowest: compound 4; then compounds 2 and 1 (each within the scatter of the next). At a limit, above all of these: compound 3.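

In this assay, the group on the amine nitrogen can clearly change the result: cyclohexyl in place of sec-butyl gives a 3.3-fold lower number from compound 2 to compound 4 (0.51 log units; beyond the scatter) and cyclohexyl in place of isobutyl gives a 5.0-fold lower number from compound 1 to compound 4 (0.70 log units; beyond the scatter) in the same direction. For the compounds shown here, the swap between the two open chains stayed within the scatter, so this is the first change here that clearly strengthens inhibition, though only modestly. Nothing shown accounts for this effect of the ring.

On these data alone, whether a cyclopentyl or a phenyl group on this nitrogen would do as well remains open. So does the effect of a longer chain.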